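A few compounds are considered here, and "the series" means these few. Any claim that something is new, unique, unknown or untested is made for them only; others in the source may bear on it.

Working notes on the series. In a functional assay on HL-60 cells (Homo sapiens) for cytotoxicity, read by MTT assay, with a stated time of 4 days (on this read-out lower numbers stand for stronger inhibition and higher numbers for weaker inhibition), compound 1 `Cc1ccc(S(=O)(=O)Oc2ccc3c(c2C)[C@H](Cn2cc(-c4ccc(Cl)cc4)nn2)[C@@]24CC(=O)[C@@](C)(CC[C@@H]32)C4)cc1` reports only the assay limit of > 20000 nM. Compound 2 `C=C1C[C@]23C[C@@]1(O)CC[C@H]2c1ccc(O)c(C)c1[C@@H]3Cn1cc(-c2ccc(C(F)(F)F)cc2)nn1` gives 8950 nM in this assay. Compound 3 `C=C1C[C@]23C[C@@]1(O)CC[C@@H]2c1cccc(C)c1[C@@H]3Cn1cc(-c2ccc(Br)cc2)nn1` likewise reaches only the limit, > 20000 nM, in this assay. Compound 3 thus stands at the limit, one of two values sitting there (the limit of > 20000 nM in this assay, at which 2 of the 3 values shown sit), and no numbered step between measured compounds is available. Compound 4 `C=C1C[C@]23C[C@@]1(O)CC[C@@H]2c1cccc(C)c1[C@@H]3Cn1cc(-c2ccc(C(F)(F)F)cc2)nn1` differs from compound 3 by trifluoromethyl in place of bromo on an aromatic carbon. Compound 2 also carries trifluoromethyl and returns a number rather than a limit, but it differs from compound 4 in more than one place. The step from compound 3 to compound 4 in this assay is expected to be an at least 1.3-fold lower number from compound 3 to compound 4 (0.12 log units; that floor lies within the scatter), a modest move off the limit, within its uncertainty possibly none. Compound 4 is estimated at 15000 nM in this assay, between 5000 nM and 45000 nM.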

Compound 4, half-maximal inhibitory concentration: > 20000 nM
Compound 4: no number, only a limit; the forecaster's own chance of this, stated with the estimate: 50%; middle value at least 1.3-fold (0.12 log units) away from the limit.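

Compound 3 and compound 4 both report only a limit, so no step can be read between them: the limit of > 20000 nM in this assay, at which 3 of the 4 values shown sit.

The compounds shown leave open whether trifluoromethyl in place of bromo on an aromatic carbon changes the read-out at all.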